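Swapping the Aniline Substituent on a Weak Diaminopyrimidine

The source may hold more compounds than are shown below. What is called first, only, known or untested is meant among the compounds shown, and "the series" means these compounds.

Compound 3 `CCOc1ccc(Cl)cc1-c1cc(Nc2ccccc2Cl)nc(N)n1` gives 4900 nM in an assay on Sf9 cells for inhibition of 1-acyl-sn-glycerol-3-phosphate acyltransferase beta (Homo sapiens) (a lower number here means a stronger inhibitor, a higher number a weaker inhibitor), the highest number among the three measured compounds. Compound 1 `CCOc1ccc(Br)cc1-c1cc(Nc2ccc(C(=O)NO)cc2)nc(N)n1` gives 88 nM and compound 2 `CCOc1ccc(Br)cc1-c1cc(Nc2ccc(C(C)=O)cc2)nc(N)n1` gives 34 nM; both differ from compound 3 in more than one place, so their gaps to compound 3 are only read as values. Going by the values given here, the one single-place step, a 2.6-fold lower number from compound 1 to compound 2 (0.41 log units; beyond the scatter), concerns a carbonyl substituent and does not touch the position changed here. Compound 4 `CCOc1ccc(Cl)cc1-c1cc(Nc2cccc([N+](=O)[O-])c2)nc(N)n1` differs from compound 3 by 3-nitrophenyl in place of 2-chlorophenyl on a nitrogen on an aromatic ring. Among the compounds with values here, with no measured step bearing on this change, any expectation rests on the values alone. Compound 4 is estimated at 1500 nM (range 300 nM to 7000 nM), an expected step of a 3.3-fold lower number from compound 3 to compound 4 (0.51 log units; beyond the scatter).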

Compound 4, half-maximal inhibitory concentration: 640 nM
Compound 4: the middle estimate sits 2.3-fold (0.37 log units) above what was measured, within the range that was stated.
By their numbers in this assay, from the lowest: compound 2; then compound 1; then compound 4; then compound 3.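

Going by these compounds alone, compound 3 and compound 4 give the first step that bears directly on this position: 3-nitrophenyl in place of 2-chlorophenyl on a nitrogen on an aromatic ring gives a 7.7-fold lower number from compound 3 to compound 4 (0.88 log units; beyond the scatter). The number therefore responds to this substituent alone, with the rest of the structure unchanged. No available evidence bears on why the step has this size.

Still open, as far as these compounds go, is whether the change follows from losing the chlorine, gaining the nitro group, or the different substitution pattern, as all three come together here. Also open, from the compounds shown here alone, is how an amine or a carboxylic acid on this phenyl ring would read.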